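This account rests on a few compounds, and the source may have more. Where it says the series, first, only, none or still open, it means among the compounds named here.

Series notes. Among the measured compounds shown here, in a functional assay on the whole organism (stomach) for inhibition, with Rattus norvegicus as the target (on this read-out lower numbers stand for an effect already at smaller amounts and higher numbers for an effect only at larger amounts of compound), compound 1 `N=C(S)CCCn1nc(-c2ccccc2)ccc1=O` gives 10.5 mg/kg, the only number recorded in this read-out so far. Compound 2 `C/N=C(\S)C(C)Cn1ncccc1=O` reaches only a limit of the assay: in this assay compound 2 gives > 50 mg/kg. For the measured compounds named here, compound 2 differs from compound 1 in more than one place, so the two values show no single step; together they show one number and one limit, (the limit of > 50 mg/kg in this assay, at which 1 of the 2 values shown sits), and nothing more for this read-out. Compound 3 `CC(Cn1nc(-c2ccccc2)ccc1=O)C(=N)S` is the next compound to be run in this assay. It is an isomer of compound 1: a group of 5 heavy atoms (3 carbon, 1 nitrogen, 1 sulfur; no ring) in place of a group of 5 heavy atoms (3 carbon, 1 nitrogen, 1 sulfur; no ring), on a saturated chain carbon bound to an aromatic nitrogen. Going by the values given here, no measured pair isolates this change, so the size of the step in this assay is open; a modest shift toward larger doses is expected rather than a gain beyond the scatter. Compound 3 is expected to give 18 mg/kg, within 7 mg/kg to 50 mg/kg, which means an expected step of a 1.7-fold higher number from compound 1 to compound 3 (0.23 log units; within the scatter).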

Compound 3, dose for half-maximal effect: 36.1 mg/kg
Estimate against measurement, compound 3: 2.0-fold (0.30 log units) below, and the stated range covers the measured number.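

In this assay, among the compounds shown here, the change on a saturated chain carbon bound to an aromatic nitrogen gives the first single-place step: a 3.4-fold higher number from compound 1 to compound 3 (0.54 log units; beyond the scatter) and lies beyond the usual scatter. For the compounds shown here, the same atoms, joined differently, are enough to move the dose at this place, which the earlier compounds could not show. The group that leaves and the group that enters match in heavy atoms, double bonds, hydrogen-bond donors and acceptors, so these counts alone do not fix the result in this read-out, and no measurement shown gives a reason for the step.

The result for compound 2 (> 50 mg/kg) is a limit of the assay, and that compound differs from both compound 1 and compound 3 in more than one place, so its step cannot be read. Still open, from the compounds shown here alone, is whether the dose keeps moving with a longer chain at this place, or with an amine or a carboxylic acid in place of the group carried by compound 1 and compound 3.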